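The source may hold more compounds than are shown below. What is called first, only, known or untested is meant among the compounds shown, and "the series" means these compounds.

Compound 1 `CCOC(=O)C1=Cc2ccccc2OC1(OCc1cn(CC(=O)Nc2cccc(Cl)c2)nn1)C(F)(F)F` gives 11600 nM in a functional assay on MCF7 cells (Homo sapiens) for inhibition, read by MTT assay, with a stated time of 24 h; a lower number here means a stronger inhibitor, a higher number a weaker inhibitor. Compound 3 `CCOC(=O)C1=Cc2ccccc2OC1(OCc1cn(CC(=O)Nc2ccc(I)cc2Cl)nn1)C(F)(F)F` gives 28100 nM in this assay. For compound 2 `CCOC(=O)C1=Cc2ccccc2OC1(OCc1cn(CC(=O)Nc2ccc(C)cc2)nn1)C(F)(F)F` the this assay reports only a limit, > 150000 nM. Compound 3 thus carries the highest of the two numbers shown, with compound 1 its nearest neighbour through a 2.4-fold higher number from compound 1 to compound 3 (0.38 log units; beyond the scatter). Compound 4 `CCOC(=O)C1=Cc2ccccc2OC1(OCc1cn(-c2ccc(C)cc2)nn1)C(F)(F)F` differs from compound 3 by 4-methylphenyl in place of ((2-chloro-4-iodophenyl)carbamoyl)methyl on an aromatic nitrogen, the 4-methylphenyl now sitting on an aromatic nitrogen of a five-membered aromatic ring with 3 nitrogen. The measured steps of an at least 12-fold higher number from compound 1 to compound 2 (1.11 log units; beyond the scatter) and an at least 5.3-fold lower number from compound 2 to compound 3 (0.72 log units; beyond the scatter) concern only the group on the amide-type nitrogen, and none removes the carbamoylmethyl link, so they bear on this change only loosely. Compound 4 is therefore expected to show a 1.8-fold higher number from compound 3 to compound 4 (0.25 log units; within the scatter), with wide uncertainty. Compound 4 is estimated at 50000 nM, between 10000 nM and 200000 nM.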

Compound 4, half-maximal inhibitory concentration: 26700 nM
Compound 4: the middle estimate sits 1.9-fold (0.27 log units) above what was measured; low and high end bracket the measured number.
By their numbers in this assay, from the lowest: compound 1; then compounds 4 and 3 (each within the scatter of the next). At a limit, above all of these: compound 2.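

Setting the 4-methylphenyl directly on the aromatic nitrogen removes the carbamoyl link with its amide hydrogen, yet the reading in this assay shows no loss against the 2-chloro-4-iodophenyl amide, with a 1.1-fold lower number from compound 3 to compound 4 (0.02 log units; within the scatter). Where the same 4-methylphenyl sits on the link, the value is only a limit, so this step is a bound: an at least 5.6-fold lower number from compound 2 to compound 4 (0.74 log units; beyond the scatter). Against the 3-chlorophenyl amide the change gives a 2.3-fold higher number from compound 1 to compound 4 (0.36 log units; beyond the scatter), so the outcome of dropping the link differs with the aryl group it carried.

Open, on these data alone, is how a 3-chlorophenyl set directly on that nitrogen would read. Also open, as far as these compounds go, is whether an amine or a carboxylic acid in place of the methyl would move the number.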